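A tert-Butyl Ester Analogue in a Fatty Acid Transport Series

The compounds below may be only part of what the source reports. "The series", "measured", "known", "first", "only" and "open" are said of these compounds alone.

Compound 3 `CCn1c(CNc2ccccc2)nnc1SCC(=O)Nc1ccc(C(C)=O)cc1` carries an acetyl group on the shared core, and in an assay on isolated protein for inhibition of long-chain fatty acid transport protein 1 (Mus musculus) (a higher number here means a weaker inhibitor, a lower number a stronger inhibitor), compound 3 has no single number, its entry reading "not determined" (no result reported). Compound 2 `CCn1c(CNc2ccccc2)nnc1SCC(=O)Nc1ccc(C(=O)OC)cc1` likewise shows no result in this assay, recorded as "not determined" (no result reported). Compound 1 `CCn1c(CNc2ccccc2)nnc1SCC(=O)Nc1ccc(OC)cc1` reaches only a limit of this assay, > 10000 nM. Of the three values shown, one thus sits at the limit, (the limit of > 10000 nM in this assay, at which 1 of the 3 values shown sits), and two carry no number. Compound 4 `CCn1c(CNc2ccccc2)nnc1SCC(=O)Nc1ccc(C(=O)OC(C)(C)C)cc1` differs from compound 3 by tert-butoxy in place of methyl on a carbonyl carbon. Going by the values given here, no step between measured compounds exists in this assay, so the size of the change cannot be read from the data. With compound 1 giving only a limit at > 10000 nM, a weak result is anticipated for the series. Compound 4 is expected to give about 15000 nM in this assay, in a range from 3000 nM to 60000 nM.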

Compound 4, half-maximal inhibitory concentration: > 10000 nM
Compound 4: only a limit was reported (the forecaster's own chance of this, stated with the estimate: 65%); the middle value does not contradict the limit.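

No step can be read between compound 1 and compound 4, as each gives only a limit: the limit of > 10000 nM in this assay, at which 2 of the 4 values shown sit. In this assay the compounds shown leave open how strongly any of them inhibits.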